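Cyclohexyl extension on the ring-nitrogen ethyl chain

The compounds below may be only part of what the source reports. "The series", "measured", "known", "first", "only" and "open" are said of these compounds alone.

Measured compounds:
compound 1, `O=C1CC2(CCN(CCC3CCCCC3)CC2)Oc2c1ccc1ccccc21`, 4.5
compound 2, `CCN1CCC2(CC1)CC(=O)c1ccc3ccccc3c1O2`, 2.19
compound 3, `CCN1CCC2(CCc3ccc4ccccc4c3O2)CC1`, 2.88

Of the compounds shown here, three have been read in a physicochemical assay for lipophilicity, read by HPLC, measured as octanol-water partition, at pH 7.4; a lower number here means a more polar compound, a higher number a more lipophilic compound. Compound 2 gives 2.19. Compound 1 gives 4.5. Compound 3 gives 2.88, which is second highest of the three; its nearest neighbour is compound 2, and compound 1 stands furthest from it.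

Compound 1 and compound 2 differ in one place: cyclohexyl in place of hydrogen on a saturated chain carbon, two bonds along the chain from an amine nitrogen in a ring. This change carries a step of a number 2.31 log units higher from compound 2 to compound 1 (beyond the scatter), well beyond the scatter and the largest step in the set.

Compound 3 carries a different core from compound 2; the difference between the two cores is not broken down here. Compound 4, `c1ccc2c3c(ccc2c1)CCC1(CCN(CCC2CCCCC2)CC1)O3`, is not yet measured. It relates to compound 3 as compound 1 relates to compound 2: cyclohexyl in place of hydrogen on a saturated chain carbon, two bonds along the chain from an amine nitrogen in a ring. The place of the change is the same, word for word, in both pairs, so it is the same change made on the core of compound 3.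

Going by the values given here, with only one earlier instance to go on, the step from compound 3 to compound 4 in this assay is estimated at a number 2.32 log units higher from compound 3 to compound 4 (beyond the scatter), resting on the step of a number 2.31 log units higher from compound 2 to compound 1 (beyond the scatter) as the sole precedent. On that basis compound 4 is expected to give 5.2, with a likely range from 4.6 to 5.7.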

Compound 4, distribution coefficient: 4.74
Compound 4: the middle estimate sits 0.46 log units above what was measured; the range from low to high includes it.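

In this assay the change from hydrogen to cyclohexyl, on a saturated chain carbon two bonds along the chain from an amine nitrogen in a ring, now has two instances, a number 1.86 log units higher from compound 3 to compound 4 (beyond the scatter) and a number 2.31 log units higher from compound 2 to compound 1 (beyond the scatter) on the other core. Both steps are large and run in the same direction, so on these two cores the change carries over in sign and in rough size, though the two steps are not identical. Two pairs do not show that the step would hold on a further core or that its size can be taken as fixed, and no measurement at hand bears on why the two steps differ.

The compounds shown leave open whether the step depends on cyclohexyl itself or would also appear with a phenyl ring, a longer chain or a simple branched alkyl group at the same place. They also leave open how a terminal amine or carboxylic acid on that chain would read on each of the two cores, and whether any such group would give matching steps on both.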